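Removing the Methoxy Group from Compound 2

The source may hold more compounds than are shown below. What is called first, only, known or untested is meant among the compounds shown, and "the series" means these compounds.

Of the compounds shown here, three sharing a common core have been measured in an assay on membranes from lung (Cavia porcellus) for binding affinity to leukotriene B4 receptor (Homo sapiens), read by radioligand binding; a lower number here means a stronger inhibitor, a higher number a weaker inhibitor. Compound 1 `CCc1cc(-c2ccc(F)cc2)c(O)cc1OCCCOc1cccc(CCCCC(=O)N(C)C)c1CCC(=O)O` gives 8.6 nM. Compound 2 `CCc1cc(-c2ccc(F)cc2)c(O)cc1OCCCOc1cccc(OC)c1CCC(=O)O` gives 6.4 nM, the second highest of the three numbers, with compound 1 as its nearest neighbour and compound 3 as its furthest. Compound 3 `CCCc1c(OCCCOc2cc(O)c(-c3ccc(F)cc3)cc2CC)ccc2c1OC(C(=O)O)CC2`, which carries a different arrangement of the acid-bearing part, gives 4.4 nM; all three values lie within the scatter of one another.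

The step from compound 2 to the unmeasured compound 4 `CCc1cc(-c2ccc(F)cc2)c(O)cc1OCCCOc1ccccc1CCC(=O)O` is a single change: hydrogen in place of methoxy on an aromatic carbon. Among the compounds with values here, the one measured step that bears on it is the step at the same aromatic carbon, a 1.3-fold lower number from compound 1 to compound 2 (0.13 log units; within the scatter), where a much larger group was exchanged for the methoxy group without moving the number beyond the scatter. That position has therefore shown itself indifferent to a large change in the one comparison available, and no comparison shows what removing the group altogether does.

On that basis compound 4 is expected to stay close to compound 2, the estimated step being a 1.4-fold higher number from compound 2 to compound 4 (0.15 log units; within the scatter). The value of compound 4 in this assay is estimated at 9 nM, within a range of 3 nM to 27 nM.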

Compound 4, inhibition constant: 3.8 nM
Estimate against measurement, compound 4: 2.4-fold (0.37 log units) above; measured number inside the range.
By their numbers in this assay, from the lowest: compounds 4, 3, 2 and 1 (each within the scatter of the next, the first and the last beyond it).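

The bare position shows that the methoxy group on this aromatic carbon, ortho to a 2-carboxyethyl group, can be given up in this assay: hydrogen in place of methoxy gives a 1.7-fold lower number from compound 2 to compound 4 (0.23 log units; within the scatter), so the number stays within the scatter even with no heavy atom at this place. Within the data shown here, the position is also not wholly indifferent, since the exchange of 4-(dimethylcarbamoyl)butyl for hydrogen gives a 2.3-fold lower number from compound 1 to compound 4 (0.35 log units; beyond the scatter), the first step here to pass beyond the scatter, though only modestly, while methoxy cannot be told apart from either of the other two groups. No measurement offered here accounts for either step.

The compounds shown leave open how a small group other than methoxy, such as a fluorine atom, a hydroxyl group or an amine, would read on this same aromatic carbon. They also leave open whether the modest step tracks the length of the chain or the amide at its end, which a shorter chain, or a butyl chain ending in a carboxylic acid, could separate.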